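Styryl lactone series: adding a third methoxy group

This account rests on a few compounds, and the source may have more. Where it says the series, first, only, none or still open, it means among the compounds named here.

Measured so far:
Compound 1, `COc1ccc(/C=C/C2CC=CC(=O)O2)c(OC)c1`: 4.1 uM
Compound 2, `COc1ccc(/C=C/C2CC=CC(=O)O2)cc1OC`: 10.9 uM

Both compounds were tested in a functional assay on 786-0 cells (Homo sapiens) for inhibition, read by sulforhodamine B assay, with a stated time of 48 h; on this read-out lower numbers stand for stronger inhibition of growth and higher numbers for weaker inhibition of growth. Of the two numbers, compound 2 stands highest: in this assay compound 2 gives 10.9 uM, and its nearest neighbour, compound 1, gives 4.1 uM, a gap that lies beyond the usual scatter. Among the measured compounds shown here, no step between the two has been worked out, so only their two values speak.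

Compound 3, `COc1cc(OC)c(OC)cc1/C=C/C1CC=CC(=O)O1`, has not yet been measured in this assay. It differs from compound 2 in one place: methoxy in place of hydrogen on an aromatic carbon.

For the measured compounds named here, no step between measured compounds bears on a change of this kind, so nothing in the two values shows which way it should go. Without such a precedent the expected step of a 1.1-fold lower number from compound 2 to compound 3 (0.04 log units; within the scatter) is none beyond the scatter, with the direction open. On that basis compound 3 is estimated to give about 10 uM in this assay, within a range from 3 uM to 35 uM.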

Compound 3, concentration for growth inhibition (reported as GI): 6 uM
Compound 3: the middle estimate sits 1.7-fold (0.22 log units) above what was measured; the range from low to high includes it.
By their numbers in this assay, from the lowest: compounds 1, 3 and 2 (each within the scatter of the next, the first and the last beyond it).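

In this assay, methoxy in place of hydrogen on an aromatic carbon can now be read twice, as a 1.8-fold lower number from compound 2 to compound 3 (0.26 log units; within the scatter) and as a 1.5-fold higher number from compound 1 to compound 3 (0.17 log units; within the scatter), and neither step lies beyond the scatter. Read from compound 2, the entering methoxy stands ortho to a group of 9 heavy atoms, meta to a methoxy group and para to a methoxy group, and a third methoxy at that place is tolerated, with compound 3 lying within the scatter of both compound 1 and compound 2, although those two lie beyond the scatter of each other. Nothing at hand explains why this change stays so small in this read-out.

From the compounds shown here alone, whether this aromatic carbon stays as tolerant with an ethoxy group, a longer alkoxy chain, a hydroxyl group or an amine in place of the methoxy remains open. Also open, going by these compounds, is whether any group at this place gives a step beyond the scatter from compound 2, as the values of compound 1 and compound 2 leave room for on this read-out.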